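Expected Permeability of Compound 4 After an Aryl Ether Change

This account rests on a few compounds, and the source may have more. Where it says the series, first, only, none or still open, it means among the compounds named here.

Measured so far in an ADME assay for permeability, using PAMPA, with a stated time of 30 min, at pH 7.4; a higher number here means that the compound crosses the layer faster, a lower number that the compound crosses the layer more slowly:
compound 1, `COc1ccc(F)cc1CNCCCNc1ccnc2cc(-c3ccccc3)ccc12`, gives 237 10^-6 cm/s
compound 2, `COc1ccc(F)cc1CNCCCNc1ccnc2cc(CC3CCCCC3)ccc12`, gives 23 10^-6 cm/s
compound 3, `COc1ccc(F)cc1CNCCCNc1ccnc2cc(Oc3cccc(N(C)C)c3)ccc12`, gives 317 10^-6 cm/s

Among the measured compounds shown here, compound 3 sits at the top of the three numbers, yet the step of a 1.3-fold higher number from compound 1 to compound 3 (0.13 log units; within the scatter) is small, and only the step of a 14-fold higher number from compound 2 to compound 3 (1.14 log units; beyond the scatter) is large. Compound 4, `COc1ccc(F)cc1CNCCCNc1ccnc2cc(Oc3ccccc3OC)ccc12`, differs from compound 3 in one place: 2-methoxyphenyl in place of 3-(dimethylamino)phenyl on an oxygen on an aromatic ring. The step that bears on this is a 1.3-fold higher number from compound 1 to compound 3 (0.13 log units; within the scatter), which brought in the whole phenoxy group with little effect. For the measured compounds named here, no measured step alters the substituent on that phenoxy ring itself, so the data give no ground to expect a shift, and the estimated step is a 1.3-fold lower number from compound 3 to compound 4 (0.10 log units; within the scatter). Compound 4 is therefore expected to give about 250 10^-6 cm/s in this assay, within a range from 120 10^-6 cm/s to 500 10^-6 cm/s.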

Compound 4, apparent permeability in the ADME assay: 317 10^-6 cm/s
For compound 4 the middle estimate is 1.3-fold (0.10 log units) below the measured one, within the range that was stated.
By their numbers in the ADME assay, from the lowest: compound 2; then compounds 1, 3 and 4 (each within the scatter of the next).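

In the ADME assay, swapping 3-(dimethylamino)phenyl for 2-methoxyphenyl on the oxygen gives no change at the digits printed from compound 3 to compound 4 (within the scatter), the only change shown on that outer ring. The other steps repeat the earlier picture: a 1.3-fold higher number from compound 1 to compound 4 (0.13 log units; within the scatter) and a 14-fold higher number from compound 2 to compound 4 (1.14 log units; beyond the scatter) leave the cyclohexylmethyl compound alone at the low end. In a physicochemical assay for solubility, with a stated time of 18 h, at pH 7.4 (on this read-out higher numbers stand for higher solubility and lower numbers for lower solubility), compound 3 gives 14500 nM and compound 4 gives 14500 nM, which is no change at the digits printed from compound 3 to compound 4 (within the scatter).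

No evidence here gives a reason for this flat result. As far as these compounds go, whether a carboxylic acid on that ring would leave both read-outs as steady stays open.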